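The source may hold more compounds than are shown below. What is called first, only, known or untested is meant among the compounds shown, and "the series" means these compounds.

Three esters that share one core have been measured in a functional assay on MCF7 cells (Homo sapiens) for antiproliferative activity, read by sulforhodamine B assay, with a stated time of 48 h, tested at 50 uM; on this read-out higher numbers stand for more inhibition at the one concentration tested (going by the name of the read-out) and lower numbers for less inhibition. Compound 1 `COc1cccc(C(=O)Oc2cc3c(cc2C)[C@@H](C(C)C)CC=C3C)c1` gives 11.9%. Compound 2 `CC1=CC[C@H](C(C)C)c2cc(C)c(OC(=O)c3ccccc3)cc21` gives 60.7%, and compound 3 `CC1=CC[C@H](C(C)C)c2cc(C)c(OC(=O)c3ccc(Cl)cc3)cc21` gives 79.7%. Compound 3 therefore stands highest of the three, with compound 2 nearest and compound 1 furthest behind it. The single-change steps read a number 48.8 percentage points higher from compound 1 to compound 2 (beyond the scatter), a number 19 percentage points higher from compound 2 to compound 3 (beyond the scatter) and a number 67.8 percentage points higher from compound 1 to compound 3 (beyond the scatter).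

Compound 4 `CC1=CC[C@H](C(C)C)c2cc(C)c(OC(=O)c3cccc(C)c3)cc21` has not yet been measured in this assay. It differs from compound 3 in one place: 3-methylphenyl in place of 4-chlorophenyl on a carbonyl carbon. Going by the values given here, two measured steps bear on this change. The step of a number 19 percentage points higher from compound 2 to compound 3 (beyond the scatter) shows what the chlorine alone added, so taking it away would by itself be expected to cost a modest amount. The step of a number 48.8 percentage points higher from compound 1 to compound 2 (beyond the scatter) shows that the one other substituted ester ring, the methoxy in compound 1, fell far below the bare ring of compound 2. A methyl is neither a methoxy nor a hydrogen, so the data do not settle which of these two cases compound 4 will resemble. Among the compounds with values here, on balance a drop beyond the scatter but smaller than the one seen for compound 1 is expected: a number 27.7 percentage points lower from compound 3 to compound 4 (beyond the scatter). For compound 4 the estimate is 52%, with a range from 22% to 78%.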

Compound 4, a percentage reported as inhibition, at one concentration (the size of the read-out at that concentration, not a potency): 54.9%
Compound 4: the middle estimate sits 2.9 percentage points below what was measured; the range from low to high includes it.
By their numbers in this assay, from the lowest: compound 1; then compounds 4 and 2 (each within the scatter of the next); then compound 3.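

In this assay the 3-methylphenyl ester of compound 4 cannot be told apart from the bare ring of compound 2, with a step of a number 5.8 percentage points lower from compound 2 to compound 4 (within the scatter), so adding this methyl to the ester ring leaves the read-out where it was. Putting methyl in place of methoxy on that ring gives a number 43 percentage points higher from compound 1 to compound 4 (beyond the scatter), which shows that the low number of compound 1 goes with the methoxy and not with just any added group on the ring, while a number 24.8 percentage points lower from compound 3 to compound 4 (beyond the scatter) shows that the 4-chlorophenyl ester keeps its lead over the methyl ester. No measurement is at hand to explain why these groups differ so sharply.

The 4-chlorophenyl and 3-methylphenyl groups differ both in the substituent and in where it sits on the ring, so the compounds shown cannot separate these two changes. They also leave open how the ester would read with an amine, a carboxylic acid or a longer alkyl chain on the ring.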